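Replacing an Ethyl Chain with a Phenyl Ring

The source may report more compounds than this note shows. Statements on the series, on what has been measured and on what is new or still open speak of the compounds shown alone.

Of the compounds shown here, three sharing a core have been measured in an assay on brain for inhibition of Amine oxidase [flavin-containing] A (Rattus norvegicus); a higher number here means a weaker inhibitor, a lower number a stronger inhibitor. Compound 1 `O=C1CSC(c2ccccc2)CN1` gives 9190 nM. Compound 2 `CCOc1ccc(C2CNCCS2)cc1` gives 2170 nM, and compound 3 `CCCOc1ccc(C2CNCCS2)cc1` gives 3690 nM. Among these three numbers compound 3 stands second highest: the step of a 1.7-fold higher number from compound 2 to compound 3 (0.23 log units; within the scatter) lies within the scatter, so compounds 2 and 3 cannot be told apart, while compound 1 stands beyond the scatter above compound 3. Compound 4 `c1ccc(COc2ccc(C3CNCCS3)cc2)cc1` has not yet been measured. It differs from compound 3 by phenyl in place of ethyl on a saturated chain carbon bound to an oxygen on an aromatic ring. Going by the values given here, the only measured step touching that chain is a 1.7-fold higher number from compound 2 to compound 3 (0.23 log units; within the scatter), where a methyl in place of a hydrogen changed little. Nothing measured shows what an aromatic ring does at this place, so the expectation rests on that single small step. Compound 4 is therefore expected to sit near compound 3, with the expected step of a 1.5-fold lower number from compound 3 to compound 4 (0.17 log units; within the scatter) uncertain in direction. The estimated value for compound 4 in this assay is 2500 nM, with a range from 600 nM to 10000 nM.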

Compound 4, inhibition constant: 19000 nM
The estimate for compound 4 lay 7.6-fold (0.88 log units) below the measured number; the whole stated range lies below it.
By their numbers in this assay, from the lowest: compounds 2 and 3 (each within the scatter of the next); then compound 1; then compound 4.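

In this assay, the saturated chain carbon bound to an oxygen on an aromatic ring turns out not to be indifferent to change: phenyl in place of ethyl gives a 5.1-fold higher number from compound 3 to compound 4 (0.71 log units; beyond the scatter), and phenyl in place of methyl gives an 8.8-fold higher number from compound 2 to compound 4 (0.94 log units; beyond the scatter). The earlier step, a 1.7-fold higher number from compound 2 to compound 3 (0.23 log units; within the scatter), showed only that one added methyl could not be told from no change, whereas these steps show that an aromatic ring here makes a weaker inhibitor, by more than the scatter. Nothing measured here accounts for this loss.

From the compounds shown here alone, whether the ring itself matters or merely the greater number of carbon atoms stays open, and a cyclohexyl or a longer chain at this place would separate the two. Also open, going by these compounds, is whether an amine or a carboxylic acid on the added phenyl would change the number.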